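Swapping the Aryl Group on the Ring Nitrogen: Compound 3

The source may hold more compounds than are shown below. What is called first, only, known or untested is meant among the compounds shown, and "the series" means these compounds.

Measured compounds:
Compound 1, `COc1ccc(C)cc1N1C(=O)CSC1c1cccc(C(=O)NCCCCc2ccccc2)c1`, gives 79% in a functional assay on SJSA-1 cells (Homo sapiens) for inhibition, read by CCK-8 assay, with a stated time of 72 h, tested at 1 uM; on this read-out higher numbers stand for more inhibition at the one concentration tested (going by the name of the read-out) and lower numbers for less inhibition.
Compound 2, `COc1cccc(OC)c1N1C(=O)CSC1c1cccc(C(=O)NCCCCc2ccccc2)c1`, gives 72% in this assay.

Compound 1 holds the higher of the two numbers, yet the step of a number 7 percentage points lower from compound 1 to compound 2 (within the scatter) is within the scatter, so the two compounds cannot be ordered on these data. Compound 3, `CC(F)(F)c1cccc(N2C(=O)CSC2c2cccc(C(=O)NCCCCc3ccccc3)c2)c1`, differs from compound 1 by a group of 10 heavy atoms (8 carbon, 2 fluorine; one six-membered aromatic ring of carbon only) in place of a group of 9 heavy atoms (8 carbon, 1 oxygen; one six-membered aromatic ring of carbon only), on an amide-type nitrogen in a ring. Within the data shown here, the only measured step touching this position is the one from compound 1 to compound 2, where a different aryl group on the same amide-type nitrogen moved the number by an amount inside the scatter. Among the measured compounds shown here, no measured step tells what a group without an oxygen does at this place, so the expectation rests on the one change seen there and carries a wide range. Compound 3 is therefore expected to give 70%, between 45% and 88%, a step of a number 9 percentage points lower from compound 1 to compound 3 (within the scatter).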

Compound 3, a percentage reported as inhibition, at one concentration (the size of the read-out at that concentration, not a potency): 68%
Estimate against measurement, compound 3: 2 percentage points above; measured number inside the range.
By their numbers in this assay, from the lowest: compounds 3, 2 and 1 (each within the scatter of the next, the first and the last beyond it).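

In this assay, among these compounds, the new aryl group on the amide-type nitrogen gives a number 11 percentage points lower from compound 1 to compound 3 (beyond the scatter), the first step at this place to lie beyond the scatter, which shows that the choice of aryl group here can move the number, if only modestly. Set against the 2,6-dimethoxyphenyl group, the same change gives a number 4 percentage points lower from compound 2 to compound 3 (within the scatter), so a group with no oxygen and no hydrogen-bond acceptor cannot be told apart from that oxygen-bearing group on these data. Nothing at hand accounts for the difference between the groups.

The compounds shown leave open whether the step follows the loss of the methoxy group or the arrival of the two fluorine atoms, as both changes come together here. They also leave open what an unsubstituted phenyl ring, or an aryl group carrying an amine or a carboxylic acid, would give at this place.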